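A few compounds are considered here, and "the series" means these few. Any claim that something is new, unique, unknown or untested is made for them only; others in the source may bear on it.

In an ADME assay on Akata cells (Homo sapiens) for cytotoxicity, with a stated time of 7 days (a higher number here means that more compound is tolerated, a lower number that less compound is tolerated), compound 3, `CCCCCOc1nc(N)nc2c1ncn2/C=C1/CC1(CO)CO`, gives > 20000 nM, which is a limit of the assay and not a number. Compound 1, `Nc1nc(NC2CCCCC2)c2ncn(/C=C3/CC3(CO)CO)c2n1`, gives > 24000 nM in this assay, again a limit rather than a number. Compound 2, `CC(C)CSc1nc(N)nc2c1ncn2/C=C1/CC1(CO)CO`, gives > 20000 nM in this assay, also a limit. Compound 3 therefore stands where every measured compound stands: at a limit, together with compound 2 at the limit of > 20000 nM in this assay, at which 2 of the 3 values shown sit, and with compound 1 at the limit of > 24000 nM in this assay, at which 1 of the 3 values shown sits. The steps among the three, from compound 1 to compound 3 a step that the two limits leave unreadable from compound 1 to compound 3, from compound 2 to compound 3 a step that the two limits leave unreadable from compound 2 to compound 3 and from compound 1 to compound 2 a step that the two limits leave unreadable from compound 1 to compound 2, cannot be read as sizes, since a step between two limits has no measurable length.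

Compound 4, `Nc1nc(N2CCCC2)c2ncn(/C=C3/CC3(CO)CO)c2n1`, differs from compound 3 in one place: pyrrolidin-1-yl in place of pentyloxy on an aromatic carbon. The three measured steps bear on this change only loosely, as each swaps one group at the same aromatic carbon, and none of them moved a value off a limit. No step beyond the scatter is therefore expected, a step that the limit leaves unreadable from compound 3 to compound 4, and compound 4 is expected to sit at a limit as well. The estimate for compound 4 in this assay is 25000 nM, with a range from 15000 nM to 60000 nM.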

Compound 4, half-maximal cytotoxic concentration: > 24000 nM
Compound 4: only a limit was reported; the forecaster's own chance of this, stated with the estimate: 85%; the middle value does not contradict the limit.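

Compound 4 also sits at a limit and not at a number, so the steps from compound 1, compound 2 and compound 3 to compound 4 cannot be read as sizes. The compounds shown leave open, in this assay, where each half-maximal cytotoxic concentration truly lies and whether changing the group on the aromatic carbon shifts it at all.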